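This account rests on a few compounds, and the source may have more. Where it says the series, first, only, none or still open, it means among the compounds named here.

Within the data shown here, compound 3 `Cc1cc(NNC(N)=S)nc(SCc2nc3ccccc3[nH]2)n1` is one of three compounds measured in a functional assay on MCF7 cells (Homo sapiens) for cytotoxicity, read by MTT assay, with a stated time of 72 h; on this read-out lower numbers stand for stronger inhibition and higher numbers for weaker inhibition. In this assay compound 3 gives only a limit, > 100000 nM. Compound 1 `COc1ccccc1Nc1cc(C)nc(SCc2nc3ccccc3[nH]2)n1` likewise gives only a limit, > 100000 nM. Among the measured compounds shown here, compound 2 `Cc1cc(Nc2ccc(F)cc2)nc(SCc2nc3ccccc3[nH]2)n1` gives 42200 nM, the one number among the three. The step of an at least 2.3-fold higher number from compound 2 to compound 3 (0.37 log units; beyond the scatter) is readable in size, whereas a step that the two limits leave unreadable from compound 1 to compound 3. Two of the three values sit at the limit of > 100000 nM in this assay, at which 2 of the 3 values shown sit, so compound 3 is fixed from one side only.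

Compound 4 `Cc1cc(N2CCCCC2)nc(SCc2nc3ccccc3[nH]2)n1` differs from compound 3 by a group of 6 heavy atoms (5 carbon, 1 nitrogen; one six-membered non-aromatic ring with 1 hetero atom) in place of a group of 5 heavy atoms (1 carbon, 3 nitrogen, 1 sulfur; no ring), on an aromatic carbon. For the measured compounds named here, no measured step puts a ring of this kind at this place; the nearest bearing comes from an at least 2.3-fold higher number from compound 2 to compound 3 (0.37 log units; beyond the scatter) and an at least 2.3-fold lower number from compound 1 to compound 2 (0.37 log units; beyond the scatter), which show that the two aromatic groups tried on that nitrogen reach at most modest inhibition. For compound 4 the expected step is an at least 1.2-fold lower number from compound 3 to compound 4 (0.09 log units; that floor lies within the scatter), with a real chance that the read-out is again a limit. Compound 4 is therefore estimated at 80000 nM, within a range of 30000 nM to 300000 nM.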

Compound 4, half-maximal inhibitory concentration: > 100000 nM
Compound 4: only a limit was reported (the forecaster's own chance of this, stated with the estimate: 55%); at least 1.2-fold (0.09 log units) between middle value and limit.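

In this assay compound 4, with a non-aromatic ring at this place, gives > 100000 nM, which is a limit, so piperidin-1-yl joins the groups here that yield no number. Among these compounds, the one readable comparison is an at least 2.3-fold higher number from compound 2 to compound 4 (0.37 log units; beyond the scatter), with piperidin-1-yl in place of (4-fluorophenyl)amino, while the steps between the limits cannot be read. Among the four compounds, only compound 2 now gives a number, and the comparisons at this place rest on that single value: the limit of > 100000 nM in this assay, at which 3 of the 4 values shown sit.

The compounds shown leave open whether morpholin-4-yl or an open-chain amine such as diethylamino at this place would give a number rather than a limit. They also leave open whether plain phenylamino would match (4-fluorophenyl)amino, and so whether the fluorine matters to the number for compound 2.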